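This account rests on a few compounds, and the source may have more. Where it says the series, first, only, none or still open, it means among the compounds named here.

Measured so far in a physicochemical assay for solubility, at pH 2; on this read-out lower numbers stand for lower solubility and higher numbers for higher solubility:
compound 1 `CNc1nc(OCCCN(C)C)c2sc(-c3ccc(C(F)(F)F)cc3)cc2n1` gives 174 ug/mL
compound 2 `CNc1nc(NC(C)(C)C)c2sc(-c3ccc(C(F)(F)F)cc3)cc2n1` gives 1.6 ug/mL

Of these two numbers, compound 2 stands lowest, and its nearest neighbour is compound 1, which is far higher: a 110-fold lower number from compound 1 to compound 2 (2.04 log units; beyond the scatter). Within the data shown here, that one step, swapping an open chain with a basic nitrogen for a (tert-butyl)amino group, is the only measured change in this small set.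

Compound 3 `CNc1nc(Nc2cccc(S(C)(=O)=O)c2)c2sc(-c3ccc(C(F)(F)F)cc3)cc2n1` has not yet been measured. It differs from compound 2 in one place: 3-(methylsulfonyl)phenyl in place of tert-butyl on a nitrogen on an aromatic ring. Unlike the earlier step, nothing basic enters or leaves here; the amine nitrogen stays, and a flat aromatic ring bearing a sulfonyl group takes the place of a small branched chain. Among the measured compounds shown here, the measured step from compound 1 to compound 2 therefore does not speak directly to this change, and no other pair in the data does. With no guide beyond the fact that the aromatic ring adds considerable size, compound 3 is expected to sit near compound 2 or somewhat lower, a 1.6-fold lower number from compound 2 to compound 3 (0.20 log units; within the scatter), a step that may not rise beyond the scatter. The estimate for compound 3 is 1 ug/mL, with a range from 0.2 ug/mL to 6 ug/mL.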

Compound 3, solubility: < 5 ug/mL
Compound 3 was reported as a limit (the forecaster's own chance of this, stated with the estimate: 20%); the middle value is on the limit's open side.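

In this assay, compound 3 is reported only as a limit, < 5 ug/mL, and not as a number. The step from compound 2 to compound 3 therefore cannot be read, as the result stops at this limit: the limit of < 5 ug/mL in this assay, at which 1 of the 3 values shown sits.

The compounds shown leave open whether 3-(methylsulfonyl)phenyl in place of tert-butyl gives a higher number, a lower one, or about the same.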